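A few compounds are considered here, and "the series" means these few. Any claim that something is new, unique, unknown or untested is made for them only; others in the source may bear on it.

Measured in a functional assay on MCF7 cells (Homo sapiens) for antiproliferative activity, read by MTT assay, with stated times of 24 h and 72 h (a higher number here means a weaker inhibitor, a lower number a stronger inhibitor), as follows:
compound 1 `COc1cc(N2C(=O)[C@@H](Oc3ccccc3)[C@H]2c2ccc(C#N)cc2)cc(OC)c1OC` gives 31600 nM
compound 2 `COc1cc([N+](=O)[O-])c([C@@H]2[C@H](Oc3ccccc3)C(=O)N2c2cc(OC)c(OC)c(OC)c2)cc1O` gives 59000 nM

Among the measured compounds shown here, compound 2 stands level with its only measured neighbour. For the measured compounds named here, the step of a 1.9-fold higher number from compound 1 to compound 2 (0.27 log units; within the scatter) is the sole guide, and it exchanges a group on the same saturated ring carbon that changes next. Compound 3 `COc1cc(N2C(=O)[C@@H](Oc3ccccc3)[C@H]2c2cccc(N)c2)cc(OC)c1OC` carries 3-aminophenyl there, and a group of 7 heavy atoms (6 carbon, 1 nitrogen; one six-membered aromatic ring of carbon only) in place of a group of 12 heavy atoms (7 carbon, 1 nitrogen, 4 oxygen; one six-membered aromatic ring of carbon only), on a saturated ring carbon is the full difference. One step is thin evidence, but it offers no ground for expecting a shift beyond the scatter. The expected change in this assay is a 1.7-fold lower number from compound 2 to compound 3 (0.23 log units; within the scatter) and no more than that. For compound 3 the estimated value is 35000 nM with 9000 nM to 100000 nM as the expected range.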

Compound 3, half-maximal inhibitory concentration: 17000 nM
Compound 3: the middle estimate sits 2.1-fold (0.31 log units) above what was measured; the range from low to high includes it.
By their numbers in this assay, from the lowest: compounds 3, 1 and 2 (each within the scatter of the next, the first and the last beyond it).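

At this saturated ring carbon the choice of aryl group can move the read-out in this assay: 3-aminophenyl gives a 3.5-fold lower number from compound 2 to compound 3 (0.54 log units; beyond the scatter) and so the series shows its first step beyond the scatter, though a modest one. Set against 4-cyanophenyl, the same group gives a 1.9-fold lower number from compound 1 to compound 3 (0.27 log units; within the scatter) and leaves these two compounds level, so only the group of compound 2 stands apart from compound 3. Nothing available explains this step.

On these data alone, whether a plain phenyl or a phenyl carrying a carboxylic acid at this carbon would go beyond the scatter of compound 3 remains open. The phenoxy and 3,4,5-trimethoxyphenyl groups stay constant throughout, so their part cannot be read.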